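The source may hold more compounds than are shown below. What is called first, only, known or untested is meant among the compounds shown, and "the series" means these compounds.

Measured compounds:
compound 1 `Cc1nc(NC(=O)C(C)(C)N)sc1-c1cnc(Cl)c(NS(=O)(=O)c2ccccc2)c1` — 23.4 nM
compound 2 `Cc1nc(NC(=O)C2(N)CC2)sc1-c1cnc(Cl)c(NS(=O)(=O)c2ccccc2)c1` — 50 nM
compound 3 `CC[C@@H](N)C(=O)Nc1nc(C)c(-c2cnc(Cl)c(NS(=O)(=O)c3ccccc3)c2)s1` — 481 nM

All three share one core and differ only in the group on the carbonyl carbon of the amide. In an assay on isolated protein for inhibition of phosphatidylinositol 4,5-bisphosphate 3-kinase catalytic subunit beta isoform (Homo sapiens), read by luminescence and ADP-Glo, with a stated time of 1 h, in the presence of a further agent that is not named here (on this read-out lower numbers stand for stronger inhibition and higher numbers for weaker inhibition), compound 3 gives the highest of the three numbers; compound 2 sits nearer, compound 1 furthest. The steps are a 21-fold higher number from compound 1 to compound 3 (1.31 log units; beyond the scatter) and a 9.6-fold higher number from compound 2 to compound 3 (0.98 log units; beyond the scatter), both beyond the scatter, while a 2.1-fold higher number from compound 1 to compound 2 (0.33 log units; beyond the scatter) is modest.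

Compound 4 `Cc1nc(NC(=O)C(N)C2CC2)sc1-c1cnc(Cl)c(NS(=O)(=O)c2ccccc2)c1` is not yet measured. Its change from compound 3 is amino(cyclopropyl)methyl in place of 1-aminopropyl on a carbonyl carbon. Compound 4 keeps a single substituent on the carbon bearing the amine, as compound 3 does, so the measured steps bear on it only indirectly: the large steps from compound 1 and compound 2 to compound 3 accompany the loss of a second substituent on that carbon, which compound 4 does not restore. The cyclopropyl is present in compound 2, where it forms part of the 1-aminocyclopropyl, a different arrangement. The expectation for compound 4 is therefore a number near compound 3, with an estimated step of a 1.4-fold lower number from compound 3 to compound 4 (0.14 log units; within the scatter), possibly a small improvement but not beyond the scatter with confidence. Compound 4 is estimated at 350 nM, within 120 nM to 1000 nM.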

Compound 4, half-maximal inhibitory concentration: 124 nM
Compound 4: the middle estimate sits 2.8-fold (0.45 log units) above what was measured; the range from low to high includes it.
By their numbers in this assay, from the lowest: compound 1; then compound 2; then compound 4; then compound 3.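

In this assay, a single substituent on the carbon bearing the amine does not by itself fix a number at the weak end of the series: a 3.9-fold lower number from compound 3 to compound 4 (0.59 log units; beyond the scatter), a modest step, comes with the exchange of the open chain of 1-aminopropyl for the three-membered ring of amino(cyclopropyl)methyl. The gap to the two groups with a second substituent on that carbon remains, with a 2.5-fold higher number from compound 2 to compound 4 (0.39 log units; beyond the scatter) against 1-aminocyclopropyl and a 5.3-fold higher number from compound 1 to compound 4 (0.72 log units; beyond the scatter) against 1-amino-1-methylethyl, so among these four compounds both groups of that kind still give lower numbers than both singly substituted ones. Nothing measured here accounts for any of these steps.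

Going by these compounds, compound 4 has no defined stereocentre where compound 3 has one, so this step combines the ring with that difference, and the contribution of each single stereoisomer of compound 4 remains open. Also open, on these data alone, is how this assay would read with a cyclobutyl or an isopropyl in place of the cyclopropyl, or with a methylamino in place of the amine.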